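Swapping dimethyl for dichloro on the anilide of compound 3

This account rests on a few compounds, and the source may have more. Where it says the series, first, only, none or still open, it means among the compounds named here.

Measured compounds:
- compound 1 `O=C(/C=C/C(=O)N1C/C(=C\c2ccccc2)C(=O)/C(=C/c2ccccc2)C1)Nc1ccc(Cl)c(Cl)c1`: 1700 nM
- compound 2 `O=C(/C=C/C(=O)N1C/C(=C\c2ccccc2)C(=O)/C(=C/c2ccccc2)C1)Nc1ccccc1`: 520 nM
- compound 3 `Cc1ccc(NC(=O)/C=C/C(=O)N2C/C(=C\c3ccc([N+](=O)[O-])cc3)C(=O)/C(=C/c3ccc([N+](=O)[O-])cc3)C2)cc1C`: 660 nM

All three share a core that carries two benzylidene arms and a fumaramide chain ending in an aryl amide. In a functional assay on Molt4/C8 cells (Homo sapiens) for cytotoxicity (on this read-out higher numbers stand for weaker inhibition and lower numbers for stronger inhibition), compound 3 gives 660 nM, the second highest of the three numbers: its value sits within the scatter of compound 2 and is clearly lower than that of compound 1.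

Compound 4 `O=C(/C=C/C(=O)N1C/C(=C\c2ccc([N+](=O)[O-])cc2)C(=O)/C(=C/c2ccc([N+](=O)[O-])cc2)C1)Nc1ccc(Cl)c(Cl)c1` differs from compound 3 in one place: 3,4-dichlorophenyl in place of 3,4-dimethylphenyl on an amide-type nitrogen.

Among the measured compounds shown here, no measured pair swaps dimethyl for dichloro directly. For the measured compounds named here, the only step that speaks to the dichlorophenyl amide is a 3.3-fold lower number from compound 1 to compound 2 (0.51 log units; beyond the scatter), which shows that, on the unsubstituted-benzylidene core, a plain phenyl gives a markedly lower number than the 3,4-dichlorophenyl. If that behaviour carries over to the nitro-bearing core, compound 4 should show a higher number than compound 3, though the dimethyl starting point is not itself a plain phenyl, so the size is uncertain. The expected step is a 2.4-fold higher number from compound 3 to compound 4 (0.38 log units; beyond the scatter), modest and toward weaker inhibition. Compound 4 is therefore estimated at 1600 nM, with a range from 700 nM to 4000 nM.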

Compound 4, half-maximal inhibitory concentration: 600 nM
For compound 4 the middle estimate is 2.7-fold (0.43 log units) above the measured one; the whole stated range lies above it.
By their numbers in this assay, from the lowest: compounds 2, 4 and 3 (each within the scatter of the next); then compound 1.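

In this assay the swap on the amide-type nitrogen gives a 1.1-fold lower number from compound 3 to compound 4 (0.04 log units; within the scatter) and so, on the core of compound 3, the 3,4-dimethylphenyl and 3,4-dichlorophenyl groups cannot be told apart. The only earlier view of the 3,4-dichlorophenyl group was a 3.3-fold lower number from compound 1 to compound 2 (0.51 log units; beyond the scatter) on the core of compound 1, measured against a plain phenyl, and the new result shows that this step cannot be taken as a general rule that the 3,4-dichlorophenyl group raises the number at this position. The two steps involve different pairs of groups on different cores, so they do not compare like with like, and no measurement here offers an explanation for the result.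

A plain phenyl on the core of compound 3 would connect the two steps directly, placing the same change on both cores. From the compounds shown here alone, it also remains open how this position responds when the aromatic ring is replaced or extended, for example by a longer alkyl chain ending in an amine, or by a phenyl ring carrying a carboxylic acid.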